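Replacing the Bromophenyl Cap with Furan-2-yl

The source may report more compounds than this note shows. Statements on the series, on what has been measured and on what is new or still open speak of the compounds shown alone.

Measured compounds:
compound 1, `CC(=O)N(C)c1ccc2[nH]c(-c3n[nH]c4ccccc34)cc2n1`: > 50000 nM
compound 2, `CN(C(=O)c1ccc(F)cc1)c1ccc2[nH]c(-c3n[nH]c4ccccc34)cc2n1`: 9650 nM
compound 3, `CN(C(=O)c1ccc(Br)cc1)c1ccc2[nH]c(-c3n[nH]c4ccccc34)cc2n1`: 4250 nM

In a functional assay on A549 cells (Homo sapiens) for antiproliferative activity, read by MTT assay, with a stated time of 72 h (a lower number here means a stronger inhibitor, a higher number a weaker inhibitor), compound 1 gives > 50000 nM, which is a limit of the assay and not a number. Compound 2 gives 9650 nM in this assay, and compound 3 gives 4250 nM. Among the two numbers shown, compound 3 has the lowest, with compound 2 nearest to it. The steps are an at least 5.1-fold lower number from compound 1 to compound 2 (0.71 log units; beyond the scatter) and an at least 11-fold lower number from compound 1 to compound 3 (1.07 log units; beyond the scatter), both beyond the scatter, while a 2.3-fold lower number from compound 2 to compound 3 (0.36 log units; beyond the scatter) is the smaller of the three.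

Compound 4, `CN(C(=O)c1ccco1)c1ccc2[nH]c(-c3n[nH]c4ccccc34)cc2n1`, differs from compound 3 in one place: furan-2-yl in place of 4-bromophenyl on a carbonyl carbon. For the measured compounds named here, the steps that bear on this change are the two from compound 1, which show that an aromatic ring on the carbonyl carbon, in place of methyl, lowers the number strongly. A furan-2-yl ring is a five-membered aromatic ring with one hetero atom and carries no halogen, so it is expected to sit between methyl and 4-bromophenyl. Compound 4 is therefore expected to give 15000 nM in this assay, within 5000 nM to 45000 nM. This amounts to an expected step of a 3.5-fold higher number from compound 3 to compound 4 (0.55 log units; beyond the scatter).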

Compound 4, half-maximal inhibitory concentration: 15500 nM
For compound 4 the middle estimate is 1.0-fold (0.01 log units) below the measured one, within the range that was stated.
By their numbers in this assay, from the lowest: compound 3; then compounds 2 and 4 (each within the scatter of the next). At a limit, above all of these: compound 1.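

In this assay, the ring on this carbonyl carbon need not be a halogen-bearing phenyl: furan-2-yl in place of methyl also gives a step beyond the scatter, an at least 3.2-fold lower number from compound 1 to compound 4 (0.50 log units; beyond the scatter). Compound 1 stands at a limit and not at a number, so this step gives only a bound on the size of the gain: the limit of > 50000 nM in this assay, at which 1 of the 4 values shown sits. Among the rings, the change costs activity against 4-bromophenyl, with a 3.6-fold higher number from compound 3 to compound 4 (0.56 log units; beyond the scatter), yet against 4-fluorophenyl it gives a 1.6-fold higher number from compound 2 to compound 4 (0.21 log units; within the scatter), so in these compounds a five-membered aromatic ring with one oxygen and no halogen cannot be told apart from 4-fluorophenyl, and only 4-bromophenyl stands clearly apart.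

The compounds shown leave open how a ring with another hetero atom, such as thiophen-2-yl, or a furan-2-yl ring carrying a bromine, would read on this carbonyl carbon. They also leave open whether the ring must be aromatic at all, a question that a cyclohexyl group or a longer chain in place of methyl would address.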